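From ethoxy to fluoro on the shared core

This account rests on a few compounds, and the source may have more. Where it says the series, first, only, none or still open, it means among the compounds named here.

Three compounds sharing one core are read in an ADME assay on HepG2 2.2.15 cells (Homo sapiens) for cytotoxicity, read by MTT assay, with a stated time of 8 days (a lower number here means that less compound is tolerated, a higher number that more compound is tolerated), and differ in a single group. Compound 1 (`COCCNc1ccc(-c2nn(Cc3ccc(C#N)cc3)c(=O)c3ccccc23)c(F)n1`) gives > 100000 nM as a limit, not a number. For the measured compounds named here, compound 2 (`CN(C)c1ccc(-c2nn(Cc3ccc(C#N)cc3)c(=O)c3ccccc23)c(F)n1`) gives 79200 nM as the only number in the set. Compound 3 (`CCOc1ccc(-c2nn(Cc3ccc(C#N)cc3)c(=O)c3ccccc23)c(F)n1`) gives > 100000 nM as a limit, not a number. Compound 3 therefore has no number, only the limit of > 100000 nM in this assay, at which 2 of the 3 values shown sit, and compound 1 sits there too.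

Compound 4 (`N#Cc1ccc(Cn2nc(-c3ccc(F)nc3F)c3ccccc3c2=O)cc1`) carries fluoro in place of ethoxy on an aromatic carbon, next to the ring nitrogen (fluoro in place of ethoxy on an aromatic carbon) and so turns 6-ethoxy-2-fluoropyridin-3-yl into 2,6-difluoropyridin-3-yl.

Three measured steps change the group at this place. Putting dimethylamino in place of (2-methoxyethyl)amino gives an at least 1.2-fold lower number from compound 1 to compound 2 (0.10 log units; that floor lies within the scatter) and putting ethoxy in place of dimethylamino gives an at least 1.2-fold higher number from compound 2 to compound 3 (0.10 log units; that floor lies within the scatter) while ethoxy in place of (2-methoxyethyl)amino gives a step that the two limits leave unreadable from compound 1 to compound 3 and none of them brings in fluoro. None shows a change beyond the scatter, so no such step is expected in this assay here. The expected step is an at least 1.2-fold lower number from compound 3 to compound 4 (0.09 log units; that floor lies within the scatter) and is estimated to stay inside the scatter. For compound 4 the estimated value is 80000 nM within an expected range of 30000 nM to 150000 nM and the assay may report only a limit.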

Compound 4, half-maximal cytotoxic concentration: > 100000 nM
Compound 4 ended at the assay's limit; the forecaster's own chance of this, stated with the estimate: 55%; middle value at least 1.2-fold (0.09 log units) away from the limit.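

In this assay this position now carries fluoro, a single heavy atom with no hydrogen-bond acceptor, and compound 4 still gives only a limit, as do compound 3 with ethoxy and compound 1 with (2-methoxyethyl)amino. Fluoro in place of dimethylamino gives an at least 1.2-fold higher number from compound 2 to compound 4 (0.10 log units; that floor lies within the scatter), the only readable step to compound 4; the steps to it from compound 3 and from compound 1 cannot be read, as both ends of each are limits. Compound 2 remains the only compound with a number, yet no step at this position is printed as beyond the scatter, and the set rests largely on a single limit: the limit of > 100000 nM in this assay, at which 3 of the 4 values shown sit.

Going by these compounds, how far the true values of compound 1, compound 3 and compound 4 lie beyond that limit stays unknown, so fluoro, ethoxy and (2-methoxyethyl)amino cannot be placed in any order. On these data alone, whether a carboxylic acid, a primary amine or a longer alkyl chain at this position would give a number in this assay also stays open.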